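A few compounds are considered here, and "the series" means these few. Any claim that something is new, unique, unknown or untested is made for them only; others in the source may bear on it.

Measured so far in a functional assay on CHO cells for agonist activity at Melanocyte-stimulating hormone receptor (Homo sapiens), read by a luciferase reporter, with a stated time of 4 h; on this read-out higher numbers stand for an effect only at larger amounts of compound and lower numbers for an effect already at smaller amounts:
compound 1 `COc1ccc(N(C(=O)CN2C=CN(c3ccccc3)C(=O)[C@@H](Cc3n[nH]c4ccccc34)C2=O)C(C)C)cc1`, 1550 nM
compound 2 `COc1ccc(N(C(=O)CN2C=CN(c3ccccc3)C(=O)C(Cc3n[nH]c4ccccc34)C2=O)C(C)C)cc1`, 29.5 nM
compound 3 `O=C1[C@@H](Cc2n[nH]c3ccccc23)C(=O)N(c2ccccc2)C=CN1CC(=O)N1CCCCc2ccccc21`, 1.59 nM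

Compound 3 carries the lowest number of the three; the gaps to compound 2 and to compound 1 are both beyond the scatter, so compound 3 stands clearly apart from the other two.

Compound 4 `COc1ccc(N(C(=O)CN2C=CN(c3ccccc3)C(=O)[C@H](Cc3n[nH]c4ccccc34)C2=O)C(C)C)cc1` differs from compound 3 by a group of 12 heavy atoms (10 carbon, 1 nitrogen, 1 oxygen; one six-membered aromatic ring of carbon only) in place of a group of 11 heavy atoms (10 carbon, 1 nitrogen; one six-membered aromatic ring of carbon only, one seven-membered non-aromatic ring with 1 hetero atom), on a carbonyl carbon. After that exchange compound 4 holds the same atoms and bonds as compound 1 and compound 2, drawn with the opposite configuration to compound 1 at the saturated ring carbon. Among the measured compounds shown here, the one measured step that bears on this is a 53-fold lower number from compound 1 to compound 2 (1.72 log units; beyond the scatter), and what separates that pair is only (the fact that one of compounds 1 and 2 is drawn with a defined configuration and the other without, at the place where they differ). Compound 2 therefore holds a mixture whose low number compound 1 alone cannot account for, which points to the configuration not present in compound 1 as the carrier of the low number. Relative to compound 2 and compound 3, the expected step for compound 4 is a 9.4-fold higher number from compound 3 to compound 4 (0.97 log units; beyond the scatter). Compound 4 is estimated at 15 nM, with a range from 5 nM to 60 nM.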

Compound 4, half-maximal effective concentration: 15.9 nM
Estimate against measurement, compound 4: 1.1-fold (0.03 log units) below; the range from low to high includes it.
By their numbers in this assay, from the lowest: compound 3; then compounds 4 and 2 (each within the scatter of the next); then compound 1.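

In this assay, the configuration at the saturated ring carbon now has a direct measure, with a 97-fold lower number from compound 1 to compound 4 (1.99 log units; beyond the scatter) for the R against the S form: the fact that compounds 1 and 4 differ only in the configuration as drawn. The form drawn without a configuration does not separate from the R form, with a 1.9-fold lower number from compound 2 to compound 4 (0.27 log units; within the scatter): the fact that one of compounds 2 and 4 is drawn with a defined configuration and the other without, at the place where they differ. With the configuration unchanged, isopropyl(4-methoxyphenyl)amino on the carbonyl carbon gives a 10-fold higher number from compound 3 to compound 4 (1.00 log units; beyond the scatter), so the group at this place affects the number independently of the configuration.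

The compounds shown leave open whether the S form loses as much when it carries the group of compound 3 as it does with isopropyl(4-methoxyphenyl)amino. They also leave open how a simpler group on the carbonyl carbon, such as dimethylamino or morpholine, would compare with the two groups seen here.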